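This account rests on a few compounds, and the source may have more. Where it says the series, first, only, none or still open, it means among the compounds named here.

Measured compounds in a functional assay on MDA-MB-435S cells (Homo sapiens) for cytotoxicity, read by MTT assay, with a stated time of 72 h; a lower number here means a stronger inhibitor, a higher number a weaker inhibitor:

Compound 1, `Cc1nnc(SCc2cc(=O)c3ccccc3o2)s1`: > 25000 nM; this is a limit of the assay and not a number.

Compound 2, `Cc1nnc(SCc2cc(=O)c3ccccc3o2)o1`: > 25000 nM; this is a limit of the assay and not a number.

Compound 3, `Nc1nnc(SCc2cc(=O)c3ccccc3o2)s1`: > 25000 nM; this is a limit of the assay and not a number.

Compound 1 therefore stands only at a limit in this assay, as do the two other compounds, all three resting at the same point, namely (the limit of > 25000 nM in this assay, at which 3 of the 3 values shown sit). The steps a step that the two limits leave unreadable from compound 1 to compound 2, a step that the two limits leave unreadable from compound 1 to compound 3 and a step that the two limits leave unreadable from compound 2 to compound 3 are all unreadable, since each joins two limits. Compound 4, `Cc1ccc2oc(CSc3nnc(C)s3)cc(=O)c2c1`, differs from compound 1 by methyl in place of hydrogen on an aromatic carbon. For the measured compounds named here, no measured step bears on this change, and nothing among the three compounds points away from the limit. Compound 4 is therefore expected to give 30000 nM, between 10000 nM and 100000 nM, a step that the limit leaves unreadable from compound 1 to compound 4 that is expected to stay within the scatter.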

Compound 4, half-maximal inhibitory concentration: > 25000 nM
Compound 4: a limit, no number (the forecaster's own chance of this, stated with the estimate: 85%); the middle value does not contradict the limit.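

No new step can be read, since compound 1 and compound 4 both stand at a limit and not at a number. The compounds shown leave open whether any change to the shared core yields a measurable value.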